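Carbonyl substituent swap: compound 3 to compound 4

The compounds below may be only part of what the source reports. "The series", "measured", "known", "first", "only" and "open" are said of these compounds alone.

Values in an ADME assay on HepG2 cells (Homo sapiens) for cytotoxicity; on this read-out higher numbers stand for lower toxicity in this test and lower numbers for higher toxicity in this test:
- compound 1 `O=C(N[C@H](/C=C/S(=O)(=O)c1ccccc1)CCc1ccccc1)c1cccc2cccnc12`: > 80000 nM (a limit of the assay)
- compound 2 `O=C(N[C@H](/C=C/S(=O)(=O)c1ccccc1)CCc1ccccc1)c1cccc2nccnc12`: 39600 nM
- compound 3 `Cc1ncn(C)c1C(=O)N[C@H](/C=C/S(=O)(=O)c1ccccc1)CCc1ccccc1`: 34400 nM

The two numeric values sit together: a 1.2-fold lower number from compound 2 to compound 3 (0.06 log units; within the scatter). Compound 1 gives only a limit. Its steps at the same place are floors: an at least 2.0-fold lower number from compound 1 to compound 2 (0.30 log units; that floor lies within the scatter) and an at least 2.3-fold lower number from compound 1 to compound 3 (0.36 log units; beyond the scatter).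

Compound 4 `O=C(N[C@H](/C=C/S(=O)(=O)c1ccccc1)CCc1ccccc1)c1ccc([N+](=O)[O-])o1` carries 5-nitrofuran-2-yl in place of 1,4-dimethyl-1H-imidazol-5-yl on a carbonyl carbon. Within the data shown here, no measured compound carries this group, so the expectation rests on the one fully sized step at this place, a 1.2-fold lower number from compound 2 to compound 3 (0.06 log units; within the scatter), and no step beyond the scatter is expected. The expected step is a 1.2-fold lower number from compound 3 to compound 4 (0.09 log units; within the scatter). In this assay the estimate for compound 4 is 28000 nM, with an expected range of 9000 nM to 75000 nM.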

Compound 4, half-maximal cytotoxic concentration: 5170 nM
Beside the measured number, compound 4's estimate is 5.4-fold (0.73 log units) above it, outside the stated range (below it).
By their numbers in this assay, from the lowest: compound 4; then compounds 3 and 2 (each within the scatter of the next). At a limit, above all of these: compound 1.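

At this place, on a carbonyl carbon whose other neighbour is an amide-type nitrogen, the group can shift this assay beyond the scatter: 5-nitrofuran-2-yl gives a 6.7-fold lower number from compound 3 to compound 4 (0.82 log units; beyond the scatter) and a 7.7-fold lower number from compound 2 to compound 4 (0.88 log units; beyond the scatter). Among these compounds, compound 2 and compound 3 lay within the scatter of each other, which makes these the first fully sized steps here beyond it. The third step, an at least 15-fold lower number from compound 1 to compound 4 (1.18 log units; beyond the scatter), is only a floor, set by a limit of the assay: the limit of > 80000 nM in this assay, at which 1 of the 4 values shown sits.

Open, from the compounds shown here alone, is whether the lower number follows the nitro group or the furan ring. A furan-2-yl carrying an amine or a nitrile in place of the nitro group would separate the two.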